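Ortho-chloro on the phenyl ring of compound 3

The compounds below may be only part of what the source reports. "The series", "measured", "known", "first", "only" and "open" are said of these compounds alone.

Measured compounds:
compound 1 `Clc1ccnc(COc2cc3n(n2)CCCC3)c1` — > 10000 nM
compound 2 `O=C(Nc1ncccc1O)c1cc2n(n1)CCCC2` — > 10000 nM
compound 3 `c1ccc(-c2cc3n(n2)CCCC3)cc1` — 1900 nM

Of the compounds shown here, three sharing one core have been tested in a functional assay on HEK293 cells for negative allosteric modulation of metabotropic glutamate receptor 5 (Rattus norvegicus), read by FLIPR and calcium flux, with a stated time of 170 s; a higher number here means a weaker inhibitor, a lower number a stronger inhibitor. Compound 1, with the structure `Clc1ccnc(COc2cc3n(n2)CCCC3)c1`, gives a limit rather than a number, > 10000 nM. Compound 2, with the structure `O=C(Nc1ncccc1O)c1cc2n(n1)CCCC2`, likewise gives only a limit, > 10000 nM. Compound 3, with the structure `c1ccc(-c2cc3n(n2)CCCC3)cc1`, is the only one to yield a measured value in this assay, 1900 nM; the other two values sit at the limit of > 10000 nM in this assay, at which 2 of the 3 values shown sit.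

Compound 4, with the structure `Clc1ccccc1-c1cc2n(n1)CCCC2`, has not yet been measured. It differs from compound 3 by chloro in place of hydrogen on an aromatic carbon. Among the compounds with values here, no measured pair with a change of this kind is available, so the size of the step can only be guessed. The expectation is a modest gain in potency, a step from compound 3 to compound 4 estimated at a 2.4-fold lower number from compound 3 to compound 4 (0.38 log units; beyond the scatter), which may still fall within the usual scatter. Compound 4 is accordingly expected to give 800 nM in this assay, with a range from 200 nM to 4000 nM.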

Compound 4, half-maximal inhibitory concentration: 2650 nM
For compound 4 the middle estimate is 3.3-fold (0.52 log units) below the measured one, within the range that was stated.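

Chloro in place of hydrogen on an aromatic carbon, ortho to a group of 9 heavy atoms, is the first single change that can be read in this assay, and it gives a 1.4-fold higher number from compound 3 to compound 4 (0.14 log units; within the scatter). The phenyl ring of compound 3 therefore accepts chloro at this position without a change beyond the scatter, and compound 4 still gives a measured value rather than a limit. Nothing measured here bears on why the step is this small.

On these data alone, it remains open whether a methoxy group, a trifluoromethyl group or an amine at this same position would give a similar result, or how chloro would fare on the other carbons of the ring. This single pair also does not show whether chloro would give a similar step on a phenyl ring that already carries another group, such as a nitrile.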